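Resolving One Stereocentre: Compound 1 to Compound 3

A few compounds are considered here, and "the series" means these few. Any claim that something is new, unique, unknown or untested is made for them only; others in the source may bear on it.

Measured compounds:
compound 1 `CCCCCC(C#CC(=O)OC)O/C=C/C(=O)OC`: 13000 nM
compound 2 `CCCCC[C@H](C#CC(=O)OC)O/C=C/C(=O)OC`: 26000 nM

In a functional assay on WiDr cells (Homo sapiens) for inhibition, with a stated time of 48 h (a higher number here means a weaker inhibitor of growth, a lower number a stronger inhibitor of growth), compound 1 gives 13000 nM, the lower of the two numbers recorded so far. Its nearest neighbour is compound 2, which in this assay gives 26000 nM, so that the step of a 2.0-fold higher number from compound 1 to compound 2 (0.30 log units; within the scatter) stays inside the scatter of the method. The step from compound 1 to compound 3 `CCCCC[C@@H](C#CC(=O)OC)O/C=C/C(=O)OC` is of the same kind: the two compounds have the same atoms and bonds; at least one stereo element is drawn with a configuration in one of them and without one in the other: 1 of 2 stereo elements differ; a stereocentre at a saturated chain carbon is drawn without a configuration in compound 1 and S in compound 3. Within the data shown here, the one measured step that bears on it is a 2.0-fold higher number from compound 1 to compound 2 (0.30 log units; within the scatter), and the only thing that separates those two compounds is the fact that one of compounds 1 and 2 is drawn with a defined configuration and the other without, at the place where they differ. With one sibling enantiomer sitting inside the scatter of the undefined compound, the expected step of a 1.3-fold lower number from compound 1 to compound 3 (0.11 log units; within the scatter) is also no larger than the scatter, in either direction. Compound 3 is therefore estimated at 10000 nM, with a range from 4000 nM to 26000 nM.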

Compound 3, concentration for 50% growth inhibition: 24000 nM
Beside the measured number, compound 3's estimate is 2.4-fold (0.38 log units) below it, within the range that was stated.
By their numbers in this assay, from the lowest: compounds 1, 3 and 2 (each within the scatter of the next).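

With compound 3 measured, both drawn configurations at the saturated chain carbon can be set against the undefined compound in this assay, and the S form gives a 1.8-fold higher number from compound 1 to compound 3 (0.27 log units; within the scatter). The earlier compounds shown here offered no direct comparison of the two defined configurations, which now comes out as a 1.1-fold lower number from compound 2 to compound 3 (0.03 log units; within the scatter). This pair isolates the stereocentre, and neither drawn configuration stands apart from the other at this position: the fact that compounds 2 and 3 differ only in the configuration as drawn.

All three compounds share the same atoms and bonds, so they say nothing about how the number responds to a change in structure rather than in configuration. On these data alone, whether a longer chain at this carbon, or a carboxylic acid in place of either ester, would give a step beyond the scatter remains open.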